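The compounds below may be only part of what the source reports. "The series", "measured", "known", "first", "only" and "open" are said of these compounds alone.

Measured compounds:
compound 1 `CCN(Cc1ccncc1)C(=S)SCc1ccc(C(=O)Nc2ccccc2N)cc1`: 71.6%
compound 2 `CC1CCN(C(=S)SCc2ccc(C(=O)Nc3ccccc3N)cc2)CC1`: 28.1%
compound 3 `CN1CCN(C(=S)SCc2ccc(C(=O)Nc3ccccc3N)cc2)CC1`: 29.6%

In a functional assay on MGC-803 cells (Homo sapiens) for antiproliferative activity, read by CCK-8 assay, with a stated time of 72 h, tested at 2 uM (on this read-out lower numbers stand for a weaker effect and higher numbers for a stronger effect at the one concentration tested), compound 3 stands second highest of the three numbers, with compound 2 within the scatter of it and compound 1 well above it. Compound 4 `Nc1ccccc1NC(=O)c1ccc(CSC(=S)N2CCCC2)cc1` differs from compound 3 in one place: pyrrolidin-1-yl in place of 4-methylpiperazin-1-yl on a thiocarbonyl carbon. For the measured compounds named here, the steps that bear on this exchange are a number 43.5 percentage points lower from compound 1 to compound 2 (beyond the scatter) and a number 42 percentage points lower from compound 1 to compound 3 (beyond the scatter), both large, and a number 1.5 percentage points higher from compound 2 to compound 3 (within the scatter), which lies within the scatter: 4-methylpiperidin-1-yl and 4-methylpiperazin-1-yl on the thiocarbonyl carbon gave much the same read-out. Compound 4 carries pyrrolidin-1-yl in that same place, so no step beyond the scatter is expected, giving a number 0.4 percentage points higher from compound 3 to compound 4 (within the scatter). Compound 4 is therefore estimated at 30%, within 15% to 50%.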

Compound 4, a percentage reported as inhibition, at one concentration (the size of the read-out at that concentration, not a potency): 27%
Compound 4: middle estimate off by 3 percentage points, on the high side; the measured number falls inside the stated range.
By their numbers in this assay, from the lowest: compounds 4, 2 and 3 (each within the scatter of the next); then compound 1.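

In this assay, the five-membered pyrrolidin-1-yl on the thiocarbonyl carbon reads like the six-membered rings, with a number 2.6 percentage points lower from compound 3 to compound 4 (within the scatter) and a number 1.1 percentage points lower from compound 2 to compound 4 (within the scatter), so this ring change leaves no visible mark among these three compounds. The pyrrolidin-1-yl group also falls as far short of the open ethyl((pyridin-4-yl)methyl)amino group as the six-membered rings, with a number 44.6 percentage points lower from compound 1 to compound 4 (beyond the scatter). Nothing available accounts for this result.

Still open, from the compounds shown here alone, is which part of the ethyl((pyridin-4-yl)methyl)amino group carries the higher number. A diethylamino or an ethyl(benzyl)amino group would begin to separate the ethyl chain from the pyridin-4-yl ring.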